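Methyl for Fluoro on the Thiourea Aryl Ring

A few compounds are considered here, and "the series" means these few. Any claim that something is new, unique, unknown or untested is made for them only; others in the source may bear on it.

Compound 2 `COc1ccc(-c2nn(-c3ccccc3)cc2C(=O)NC(=S)Nc2ccc(F)cc2)cc1` was examined in a functional assay on NCI-H460 cells (Homo sapiens) for inhibition, read by CCK-8 assay, with a stated time of 48 h (a lower number here means a stronger inhibitor, a higher number a weaker inhibitor), where compound 2 gives 3050 nM. For the measured compounds named here, the only other measured compound, compound 1 `Cc1ccc(NC(=S)NC(=O)c2cn(-c3ccccc3)nc2-c2ccc(Cl)cc2)cc1`, gives 3120 nM in this assay; the two numbers lie within the usual scatter of each other, so neither compound can be called the stronger inhibitor. Compound 3 `COc1ccc(-c2nn(-c3ccccc3)cc2C(=O)NC(=S)Nc2ccc(C)cc2)cc1` has not yet been measured. It differs from compound 2 by methyl in place of fluoro on an aromatic carbon, para to a large group. Going by the values given here, no pair of measured compounds differs by this change alone, so the step cannot be read off directly. Compound 1 already carries a (4-methylphenyl)amino group, and since compound 1 gives 3120 nM close to compound 2, little movement is expected. The expected step is a 1.0-fold lower number from compound 2 to compound 3 (0.01 log units; within the scatter), none beyond the scatter. Compound 3 is therefore estimated at 3000 nM, within a range from 1500 nM to 6000 nM.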

Compound 3, half-maximal inhibitory concentration: 2880 nM
For compound 3 the middle estimate is 1.0-fold (0.02 log units) above the measured one; low and high end bracket the measured number.
By their numbers in this assay, from the lowest: compounds 3, 2 and 1 (each within the scatter of the next).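

In this assay the position now has a direct reading: exchanging 4-fluorophenyl for 4-methylphenyl gives a 1.1-fold lower number from compound 2 to compound 3 (0.02 log units; within the scatter), so with the rest of the molecule held constant, these two groups cannot be told apart. The second single change, methoxy in place of chloro on an aromatic carbon with the 4-methylphenyl group kept, gives a 1.1-fold lower number from compound 1 to compound 3 (0.03 log units; within the scatter), so this exchange does not separate its two compounds either. Nothing measured here bears on why the numbers stay so close.

The compounds shown carry only fluoro or methyl at this position, so it remains open whether an amine, a carboxylic acid or a longer chain such as butyl would read the same. Also open, from the compounds shown here alone, is how a hydroxyl group would read in place of the methoxy or chloro group.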